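The source may hold more compounds than are shown below. What is called first, only, known or untested is meant among the compounds shown, and "the series" means these compounds.

In a physicochemical assay for solubility (on this read-out higher numbers stand for higher solubility and lower numbers for lower solubility), compound 1 `CNC(=O)c1cc(C(=O)NC2CC2)cn(Cc2cccc3[nH]ccc23)c1=O` gives 78 ug/mL. Compound 2 `CNC(=O)c1cc(C(=O)NC2CC2)cn(Cc2cccc3c2CCN3)c1=O` reads >= 184 ug/mL, which is a limit of the assay and not a number. Compound 3 `CNC(=O)c1cc(C(=O)NC2CC2)cn(Cc2cccc3occc23)c1=O` has 1-benzofuran-4-yl in place of 2,3-dihydro-1H-indol-4-yl on a saturated chain carbon bound to an aromatic nitrogen. Among the measured compounds shown here, the one measured step bearing on this change is an at least 2.3-fold higher number from compound 1 to compound 2 (0.37 log units; beyond the scatter). With a five-membered aromatic ring back in compound 3, a reversal of that step is expected, of similar size or somewhat larger, towards lower numbers in this assay. The expected step is an at least 3.3-fold lower number from compound 2 to compound 3 (0.52 log units; beyond the scatter). For compound 3 the estimate is 55 ug/mL, with an expected range from 18 ug/mL to 140 ug/mL.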

Compound 3, solubility: >= 110 ug/mL
Compound 3 ended at the assay's limit; the forecaster's own chance of this, stated with the estimate: 5%; at least 2.0-fold (0.30 log units) between middle value and limit.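

Replacing 1H-indol-4-yl with 1-benzofuran-4-yl in this assay gives an at least 1.4-fold higher number from compound 1 to compound 3 (0.14 log units; that floor lies within the scatter), a floor only. Compound 3 ends at a limit of the assay, so a non-aromatic five-membered ring, as in compound 2, is not the only form at this place that ends at a limit. Compound 2 also ends at a limit, and the step between these two compounds cannot be read.

Going by these compounds, how far compound 2 and compound 3 lie beyond their limits remains open. So does the reading of an amine or a carboxylic acid at this place.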